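Swapping Fluorine for Chlorine on a Phenyl Ring

The source may report more compounds than this note shows. Statements on the series, on what has been measured and on what is new or still open speak of the compounds shown alone.

Among the measured compounds shown here, compound 1 `CCOC(=O)c1cnn(-c2nc(-c3ccccc3F)c(C#N)c(=O)n2C)c1N` is one of three compounds measured in a functional assay, with a stated time of 150 min; a higher number here means a weaker inhibitor, a lower number a stronger inhibitor. In this assay compound 1 gives 87 ug/mL. Its two companions are compound 2 `CSc1nc(-c2ccco2)c(C#N)c(=O)n1C`, which gives 108 ug/mL, and compound 3 `CSc1nc(-c2ccccc2O)c(C#N)c(=O)n1C`, which gives 58 ug/mL. All three numbers sit within the usual scatter of one another, so none of these compounds can be called stronger or weaker than the others on the present data.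

Compound 4 `CCOC(=O)c1cnn(-c2nc(-c3ccccc3Cl)c(C#N)c(=O)n2C)c1N` has not yet been measured. It differs from compound 1 in a single place: chloro in place of fluoro on an aromatic carbon. For the measured compounds named here, no pair of measured compounds shows this same exchange, so there is no measured step to lean on, and nothing among the measured compounds indicates which way the number should move. Compound 4 is therefore expected to give a value close to that of compound 1, estimated at 80 ug/mL, with a plausible range from 40 ug/mL to 160 ug/mL. The step this estimate implies, a 1.1-fold lower number from compound 1 to compound 4 (0.04 log units; within the scatter), is expected to stay within the scatter.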

Compound 4, half-maximal inhibitory concentration: 93 ug/mL
Beside the measured number, compound 4's estimate is 1.2-fold (0.07 log units) below it; measured number inside the range.
By their numbers in this assay, from the lowest: compounds 3, 1, 4 and 2 (each within the scatter of the next).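

In this assay the change from 2-fluorophenyl to 2-chlorophenyl gives a 1.1-fold higher number from compound 1 to compound 4 (0.03 log units; within the scatter) and is the only one-place step among these compounds. At this aromatic carbon, ortho to a large group, one halogen can therefore replace the other with no change that this assay can separate from the scatter. Nothing shown here offers an explanation for this result.

Among the compounds shown here, the step covers only this one exchange of single atoms, so it remains open whether a different kind of group at the same carbon, such as an amine, a carboxylic acid or a longer chain, would move the number beyond the scatter. As far as these compounds go, it also remains open whether the same exchange would behave alike on a phenyl ring attached to a different core.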